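The source may report more compounds than this note shows. Statements on the series, on what has been measured and on what is new or still open speak of the compounds shown alone.

In an ADME assay on C8166 cells (Homo sapiens) for cytotoxicity, read by MTT assay (on this read-out lower numbers stand for higher toxicity in this test and higher numbers for lower toxicity in this test), compound 2 `Cc1cc(S(N)(=O)=O)ccc1NC(=O)COc1ccc(Cl)cc1C(O)c1cccc(C)c1C` gives 218000 nM, the highest number among the three compounds measured; compound 1 `Cc1ccc(C(O)c2cc(Cl)ccc2OCC(=O)Nc2ccc(S(N)(=O)=O)cc2C)cc1` gives 38700 nM and compound 3 `Cc1cc(S(N)(=O)=O)ccc1NC(=O)COc1ccc(Cl)cc1C(O)c1cc(Cl)cc(Br)c1` gives 22900 nM. Compound 4 `Cc1cc(S(N)(=O)=O)ccc1NC(=O)COc1ccc(Cl)cc1C(O)c1ccc2ccccc2c1` has not yet been measured and differs from compound 2 by naphthalen-2-yl in place of 2,3-dimethylphenyl on a saturated chain carbon bound to an aromatic carbon and an oxygen on a saturated carbon. Two measured steps change the same group at the same place: a 5.6-fold higher number from compound 1 to compound 2 (0.75 log units; beyond the scatter) and a 9.5-fold lower number from compound 2 to compound 3 (0.98 log units; beyond the scatter). In both, compound 2 with its 2,3-dimethylphenyl stands higher than the compound carrying the other aryl group. A naphthalen-2-yl in its place is therefore expected to give a lower number than compound 2, with compound 4 estimated to show a 6.2-fold lower number from compound 2 to compound 4 (0.79 log units; beyond the scatter). Compound 4 is estimated at 35000 nM, within a range from 10000 nM to 120000 nM.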

Compound 4, half-maximal cytotoxic concentration: 15700 nM
Compound 4: middle estimate off by 2.2-fold (0.35 log units), on the high side, and the stated range covers the measured number.
By their numbers in this assay, from the lowest: compounds 4, 3 and 1 (each within the scatter of the next, the first and the last beyond it); then compound 2.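

In this assay, the change to naphthalen-2-yl gives a 14-fold lower number from compound 2 to compound 4 (1.14 log units; beyond the scatter) and so places compound 2 above all three other aryl groups at this position. The 2,3-dimethylphenyl group is thus the one that stands apart, while a 2.5-fold lower number from compound 1 to compound 4 (0.39 log units; beyond the scatter) also sets naphthalen-2-yl below 4-methylphenyl, and a 1.5-fold lower number from compound 3 to compound 4 (0.16 log units; within the scatter) leaves naphthalen-2-yl and 3-bromo-5-chlorophenyl indistinguishable. Nothing available explains why these aryl groups differ.

On these data alone, whether both methyl groups of compound 2 are needed remains open. So does the effect of an aryl ring carrying an amine or a carboxylic acid at this place.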